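Trading 3-ethylphenyl for 3,5-dimethylphenyl on a sulfonamide nitrogen

The compounds below may be only part of what the source reports. "The series", "measured", "known", "first", "only" and "open" are said of these compounds alone.

Measured in a functional assay on M21 cells (Homo sapiens) for antiproliferative activity, read by sulforhodamine B assay, with a stated time of 48 h; on this read-out lower numbers stand for stronger inhibition and higher numbers for weaker inhibition:
- compound 1 `CCc1ccc(NS(=O)(=O)c2ccc(N3CCNC3=O)cc2)cc1`: 480 nM
- compound 2 `O=C1NCCN1c1ccc(S(=O)(=O)Nc2ccccc2)cc1`: 200 nM
- compound 3 `CCc1cccc(NS(=O)(=O)c2ccc(N3CCNC3=O)cc2)c1`: 82 nM

Among these three, compound 3 has the lowest number, 82 nM, and its steps to both of the others lie beyond the scatter. It is therefore the strongest inhibitor so far. The next candidate, compound 4 `Cc1cc(C)cc(NS(=O)(=O)c2ccc(N3CCNC3=O)cc2)c1`, keeps the shared core and differs only in the group on the sulfonamide nitrogen: 3,5-dimethylphenyl in place of 3-ethylphenyl on a sulfonamide nitrogen. The two compounds have the same atoms, joined differently.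

Among the measured compounds shown here, no measured step tests a 3,5-dimethylphenyl group directly, so the evidence is indirect. Putting hydrogen in place of ethyl gives a 2.4-fold lower number from compound 1 to compound 2 (0.38 log units; beyond the scatter). Putting ethyl back, now as 3-ethylphenyl, gives a 2.4-fold lower number from compound 2 to compound 3 (0.39 log units; beyond the scatter). Exchanging 4-ethylphenyl for 3-ethylphenyl gives a 5.9-fold lower number from compound 1 to compound 3 (0.77 log units; beyond the scatter), the largest of the three, though still modest. The new group also has a substituent numbered 3 in its name, the numbering that went with the lower value in that last step. A step beyond the scatter in this assay is therefore not expected, only a slight drift towards a higher number.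

The expected change is a 1.2-fold higher number from compound 3 to compound 4 (0.09 log units; within the scatter). For compound 4 the estimated value is 100 nM, with an expected range of 35 nM to 300 nM.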

Compound 4, half-maximal inhibitory concentration: 63 nM
Beside the measured number, compound 4's estimate is 1.6-fold (0.20 log units) above it; the range from low to high includes it.
By their numbers in this assay, from the lowest: compounds 4 and 3 (each within the scatter of the next); then compound 2; then compound 1.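

In this assay, rearranging the same eight carbons from 3-ethylphenyl into 3,5-dimethylphenyl on the sulfonamide nitrogen gives a small difference (a 1.3-fold lower number from compound 3 to compound 4 (0.11 log units; within the scatter)), so the two groups cannot be told apart here, and neither compound can be ranked above the other. The new group does stand clearly apart from plain phenyl (a 3.2-fold lower number from compound 2 to compound 4 (0.50 log units; beyond the scatter)) and from 4-ethylphenyl (a 7.6-fold lower number from compound 1 to compound 4 (0.88 log units; beyond the scatter)), so a second substituted group now sits below phenyl in this assay, and among these four compounds, both groups with a substituent numbered 3 give lower numbers than phenyl, whereas 4-ethylphenyl, the one compound that goes the other way, gives a higher number. Nothing measured here explains why these groups differ in this way.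

From the compounds shown here alone, all four groups on the sulfonamide nitrogen are phenyl rings carrying only hydrogen, methyl or ethyl, so it remains open whether a methoxy group, a chlorine atom or an amine would serve as well. Among the compounds shown here, also open is what 3-methylphenyl, with its single methyl group, or 3-propylphenyl, with its longer chain, would give.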